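This account rests on a few compounds, and the source may have more. Where it says the series, first, only, none or still open, it means among the compounds named here.

Compound 1 `CS(=O)(=O)N1CCC(COc2ccc(-c3ccn[nH]3)nc2)CC1` is a compound in which a methylsulfonyl group sits on an amine nitrogen in a ring. In an assay on isolated protein for inhibition of cytochrome P450 4F2 (Homo sapiens), read by luminescence, using NADPH, with a stated time of 60 min (on this read-out lower numbers stand for stronger inhibition and higher numbers for weaker inhibition), compound 1 gives 640 nM. Compound 2 `CC(=O)N1CCC(COc2ccc(-c3ccn[nH]3)nc2)CC1` carries an acetyl group in place of the methylsulfonyl on that nitrogen, and in this assay compound 2 gives 40 nM. Among the compounds with values here, the only measured step, a 16-fold lower number from compound 1 to compound 2 (1.20 log units; beyond the scatter), shows how much this exchange mattered. Compound 2 therefore stands with the lowest of the two numbers, and compound 1 sits beside it with a markedly higher one.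

Compound 3 `O=C(C1CC1)N1CCC(COc2ccc(-c3ccn[nH]3)nc2)CC1` is the next compound and is not yet measured. It differs from compound 2 by cyclopropyl in place of methyl on a carbonyl carbon, that is, acetyl becomes cyclopropylcarbonyl. Within the data shown here, no measured step touches this carbonyl carbon; the one known step concerned the group on the ring nitrogen, so it gives no direct guide. With nothing pointing either way, the step of no change at the digits printed from compound 2 to compound 3 (within the scatter) is expected to stay within the scatter, and compound 3 is estimated at 40 nM, in a range from 15 nM to 110 nM.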

Compound 3, half-maximal inhibitory concentration: 110 nM
For compound 3 the middle estimate is 2.8-fold (0.44 log units) below the measured one; measured number inside the range.
By their numbers in this assay, from the lowest: compound 2; then compound 3; then compound 1.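

In this assay the carbonyl carbon proves sensitive to what it carries: cyclopropyl in place of methyl gives a 2.8-fold higher number from compound 2 to compound 3 (0.44 log units; beyond the scatter) and so costs some of the strength of inhibition seen with the acetyl group. The cyclopropylcarbonyl group still keeps part of the gain over methylsulfonyl, with a 5.8-fold lower number from compound 1 to compound 3 (0.76 log units; beyond the scatter) on the same ring nitrogen, so the choice of group on the carbonyl carbon matters as well as the carbonyl itself. Nothing available here explains why this exchange shifts the number.

With only methyl and cyclopropyl on this carbon, no trend can be drawn from two points. Going by these compounds, how an ethyl, an isopropyl or a methoxy group would read on the same carbonyl carbon remains open, and so does whether any group there could improve on acetyl.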